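A shorter chain on the ring amine: compound 2 to compound 3

The source may hold more compounds than are shown below. What is called first, only, known or untested is meant among the compounds shown, and "the series" means these compounds.

The series rests on a shared core carrying a hydroxamic acid, a triazole and a saturated ring bearing an amine nitrogen. Compound 1 `O=C(NO)c1cccc(-c2cn([C@H]3C[C@@H](CO)N(CCCc4ccccc4)C3)nn2)c1` is one of two mirror images. In an assay on Sf9 cells for inhibition of histone deacetylase 11 (Homo sapiens), read by fluorescence, tested at 0.5 uM (on this read-out higher numbers stand for more inhibition at the one concentration tested (going by the name of the read-out) and lower numbers for less inhibition), compound 1 gives only a limit, < 10%. Compound 2 `O=C(NO)c1cccc(-c2cn([C@@H]3C[C@H](CO)N(CCCc4ccccc4)C3)nn2)c1` is the other mirror image. In this assay compound 2 likewise gives only a limit, < 10%. The step that the two limits leave unreadable from compound 1 to compound 2 therefore cannot be sized, because the limit of < 10% in this assay, at which 2 of the 2 values shown sit, leaves both ends undetermined, even though the fact that compounds 1 and 2 differ only in the configuration as drawn makes it a pure change of configuration.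

Compound 3 `O=C(NO)c1cccc(-c2cn([C@@H]3C[C@H](CO)N(Cc4ccccc4)C3)nn2)c1` differs from compound 2 by phenyl in place of phenethyl on a saturated chain carbon bound to an amine nitrogen in a ring; read one bond further out, 3-phenylpropyl becomes benzyl. Among the measured compounds shown here, no measured step touches this change, and the single measured step is itself unreadable. Compound 2 sits at the limit, and nothing shown points to a rise beyond the scatter. Compound 3 is therefore expected to give about 5%, with a range from 0% to 18%. The expected step that the limit leaves unreadable from compound 2 to compound 3 is estimated as no movement beyond the scatter, with a further limit the most likely outcome.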

Compound 3, a percentage reported as inhibition, at one concentration (the size of the read-out at that concentration, not a potency): < 10%
Compound 3 ended at the assay's limit; the forecaster's own chance of this, stated with the estimate: 80%; the middle value lies beyond the limit too.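

Compound 3 gives < 10%, which is a limit of the assay. The step from compound 2 to compound 3 therefore cannot be read, any more than the step from compound 1 to compound 2, because all three compounds end at the same limit: the limit of < 10% in this assay, at which 3 of the 3 values shown sit.

The compounds shown leave open whether configuration, or benzyl in place of 3-phenylpropyl, changes inhibition at all.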